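A few compounds are considered here, and "the series" means these few. Any claim that something is new, unique, unknown or untested is made for them only; others in the source may bear on it.

Series notes. Compound 2 `O=[N+]([O-])c1cccc(CSc2nnc(-c3ccc4c(c3)OCCO4)n2-c2ccccc2)c1` carries the highest number of the three measured in a functional assay on HepG2 cells (Homo sapiens) for antiproliferative activity, read by MTT assay, with a stated time of 24 h; a higher number here means a weaker inhibitor, a lower number a stronger inhibitor: compound 2 gives 49300 nM. Compound 1 `O=[N+]([O-])c1ccccc1CSc1nnc(-c2ccc3c(c2)OCCO3)n1-c1ccccc1` gives 12000 nM, and compound 3 `O=[N+]([O-])c1ccc(CSc2nnc(-c3ccc4c(c3)OCCO4)n2-c2ccccc2)cc1` gives 13800 nM in this assay. The steps of a 4.1-fold higher number from compound 1 to compound 2 (0.61 log units; beyond the scatter) and a 3.6-fold lower number from compound 2 to compound 3 (0.55 log units; beyond the scatter) both set compound 2 apart, whereas a 1.2-fold higher number from compound 1 to compound 3 (0.06 log units; within the scatter) shows nothing beyond the scatter. Compound 4 `Fc1ccc(CSc2nnc(-c3ccc4c(c3)OCCO4)n2-c2ccccc2)cc1` is not yet measured. Its difference from compound 2 is 4-fluorophenyl in place of 3-nitrophenyl on a saturated chain carbon bound to a sulfur. Of the measured steps, a 3.6-fold lower number from compound 2 to compound 3 (0.55 log units; beyond the scatter) bears most directly: it too removes the 3-nitrophenyl. Among the compounds with values here, nothing measured compares a nitrophenyl with a fluorophenyl, so the arrival of the 4-fluorophenyl has no precedent. The expectation is a lower number for compound 4, of roughly the size seen in a 3.6-fold lower number from compound 2 to compound 3 (0.55 log units; beyond the scatter), with wide uncertainty. The estimated step is a 3.3-fold lower number from compound 2 to compound 4 (0.52 log units; beyond the scatter). Compound 4 is estimated at 15000 nM in this assay, within a range of 5000 nM to 45000 nM.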

Compound 4, half-maximal inhibitory concentration: 1020 nM
For compound 4 the middle estimate is 15-fold (1.17 log units) above the measured one; the whole stated range lies above it.
By their numbers in this assay, from the lowest: compound 4; then compounds 1 and 3 (each within the scatter of the next); then compound 2.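

The cleanest reading of this position is the change of nitro to fluoro on an aromatic carbon (a 14-fold lower number from compound 3 to compound 4 (1.13 log units; beyond the scatter)), which shows that the group on this ring can move the number in this assay further than any shift of the nitro among the three measured nitrophenyl compounds did. The steps from the other two nitrophenyl compounds are also large (a 12-fold lower number from compound 1 to compound 4 (1.07 log units; beyond the scatter) and a 48-fold lower number from compound 2 to compound 4 (1.68 log units; beyond the scatter)), so compound 4 stands clear of all three, including compound 2, the one set apart earlier. Nothing in hand gives a reason for the size of these steps.

As far as these compounds go, whether the gain comes with fluoro itself or with the loss of nitro stays open, since an unsubstituted phenyl, a chloro or a methoxy on the same aromatic carbon would be needed to separate the two. Also open, from the compounds shown here alone, is whether the order seen among the nitrophenyl compounds carries over to fluorophenyl compounds.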